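The compounds below may be only part of what the source reports. "The series", "measured", "known", "first", "only" and "open" are said of these compounds alone.

Measured compounds in a functional assay on cells (blood, Homo sapiens) for inhibition, read by chemiluminescence, with a stated time of 30 min; on this read-out higher numbers stand for weaker inhibition and lower numbers for stronger inhibition:
Compound 1, `CCCCSC(=S)C1=C(Nc2ccc(Cl)cc2)CC(C)(C)CC1=O`: > 100 ug/mL, a limit of the assay.
Compound 2, `CC1(C)CC(=O)C(C(=S)SCc2ccccc2)=C(Nc2ccc(Cl)cc2)C1`: > 100 ug/mL, a limit of the assay.
Compound 3, `CCCCSC(=S)C1=C(Nc2ccc(Br)cc2)CC(C)(C)CC1=O`: > 100 ug/mL, a limit of the assay.

Compound 3 thus sits at the limit, as do the other two; none of the three gives a number, and every value rests at the limit of > 100 ug/mL in this assay, at which 3 of the 3 values shown sit. Compound 4, `CC1(C)CC(=O)C(C(=S)SCc2ccccc2)=C(Nc2ccc(Br)cc2)C1`, is not yet measured. It differs from compound 3 by phenyl in place of propyl on a saturated chain carbon bound to a sulfur. The same change appears in the step that the two limits leave unreadable from compound 1 to compound 2, where both ends are limits and the size is not readable. The other step, a step that the two limits leave unreadable from compound 1 to compound 3, is likewise unreadable. Nothing measured therefore points to a change beyond the scatter in this assay; the expected step is a step that the limit leaves unreadable from compound 3 to compound 4. Compound 4 is estimated to give 150 ug/mL, within a range from 60 ug/mL to 400 ug/mL, and is most likely to be reported again only as a limit.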

Compound 4, half-maximal inhibitory concentration: > 100 ug/mL
Compound 4 ended at the assay's limit (the forecaster's own chance of this, stated with the estimate: 85%); the middle value is on the limit's open side.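

Neither step, from compound 3 to compound 4 or from compound 2 to compound 4, can be read, as all these compounds sit at the same limit: the limit of > 100 ug/mL in this assay, at which 4 of the 4 values shown sit.

The compounds shown leave open whether bromo versus chloro or butyl versus benzyl changes inhibition at all.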